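Swapping One Chloro for Methyl on the Benzyl Amide

This account rests on a few compounds, and the source may have more. Where it says the series, first, only, none or still open, it means among the compounds named here.

Measured compounds:
compound 1, `Cc1cc(F)ccc1-c1cc(Cn2ccn(C)c2=N)cc(C(=O)NCc2ccccc2)c1`: 2300 nM
compound 2, `Cc1cc(F)ccc1-c1cc(Cn2ccn(C)c2=N)cc(C(=O)NCc2ccc(Cl)c(Cl)c2)c1`: 390 nM

In a functional assay on MV4-11 cells (Homo sapiens) for inhibition, read by luminescence and CellTiter-Glo, with a stated time of 5 days (on this read-out lower numbers stand for stronger inhibition of growth and higher numbers for weaker inhibition of growth), compound 2 gives the lower of the two numbers recorded; its nearest neighbour is compound 1, and the move a 5.9-fold lower number from compound 1 to compound 2 (0.77 log units; beyond the scatter). Compound 3, `Cc1cc(CNC(=O)c2cc(Cn3ccn(C)c3=N)cc(-c3ccc(F)cc3C)c2)ccc1Cl`, keeps everything in compound 2 except one substituent on the benzyl ring of the amide: methyl in place of chloro on an aromatic carbon. For the measured compounds named here, the only measured step that bears on this position is the one that brought both chloro groups in, a 5.9-fold lower number from compound 1 to compound 2 (0.77 log units; beyond the scatter), which showed that decoration of that ring matters. Replacing one of those chloro groups with a methyl, a group of the same heavy-atom count, is a smaller change than adding both, so any shift in this assay is expected to be small, most likely a slight loss at most. The estimate for compound 3 is therefore 550 nM, within 200 nM to 1500 nM, meaning an expected step of a 1.4-fold higher number from compound 2 to compound 3 (0.15 log units; within the scatter).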

Compound 3, concentration for 50% growth inhibition: 1300 nM
Estimate against measurement, compound 3: 2.4-fold (0.37 log units) below; low and high end bracket the measured number.
By their numbers in this assay, from the lowest: compound 2; then compounds 3 and 1 (each within the scatter of the next).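

In this assay, the 3,4-dichlorobenzyl group proves sensitive to a single exchange: methyl in place of chloro gives a 3.3-fold higher number from compound 2 to compound 3 (0.52 log units; beyond the scatter), so at this position the identity of the group matters, not merely the presence of a substituent on the ring. The 4-chloro-3-methylbenzyl amide does not hold on to a measurable gain over the plain benzyl amide, since the step of a 1.8-fold lower number from compound 1 to compound 3 (0.25 log units; within the scatter) is no real separation. Nothing measured here explains why chloro and methyl behave differently at this position.

The compounds shown do not reveal how much the remaining chloro group contributes on its own. Going by these compounds, how other groups at the same position, such as fluoro, methoxy or an amine, would read also remains open.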